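This account rests on a few compounds, and the source may have more. Where it says the series, first, only, none or still open, it means among the compounds named here.

Among the measured compounds shown here, in a functional assay on thoracic aorta (Mus musculus, strain C57Bl6) for inhibition (on this read-out lower numbers stand for stronger inhibition and higher numbers for weaker inhibition), compound 1 `Cc1ccc(C)c(OCCCCC(=O)O)c1` gives 812000 nM, the only actual number in this small set. Compound 2 `Cc1ccc(C)c(OCCCCCC(=O)O)c1`, with carboxymethyl in place of carboxy, gives > 1000000 nM, and this is a limit of the assay, not a number. For the measured compounds named here, the one measured step is an at least 1.2-fold higher number from compound 1 to compound 2 (0.09 log units; that floor lies within the scatter). It concerns only the change at the acid end of the chain and gives no measured guide to a side branch.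

Compound 3 `CCCCCCC(CCCOc1cc(C)ccc1C)C(=O)O` keeps the core of compound 1 and differs at one place: hexyl in place of hydrogen on a saturated chain carbon bound to a carbonyl carbon and a saturated chain carbon. This is hexyl in place of hydrogen on a saturated chain carbon bound to a carbonyl carbon and a saturated chain carbon. Going by the values given here, no measured step covers such a change, so the expectation rests mainly on the starting point. With compound 1 at 812000 nM, there is more readable room toward stronger inhibition than toward weaker inhibition in this assay. A step toward stronger inhibition is therefore expected, though its size is very uncertain. The estimated change is a 6.8-fold lower number from compound 1 to compound 3 (0.83 log units; beyond the scatter). For compound 3, the expected value is 120000 nM, with an estimated range of 20000 nM to 650000 nM.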

Compound 3, half-maximal inhibitory concentration: 45000 nM
Beside the measured number, compound 3's estimate is 2.7-fold (0.43 log units) above it; low and high end bracket the measured number.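

In this assay, hexyl in place of hydrogen on a saturated chain carbon bound to a carbonyl carbon and a saturated chain carbon gives an 18-fold lower number from compound 1 to compound 3 (1.26 log units; beyond the scatter). Among the compounds shown here, this is the first step in the set that is printed as beyond the scatter, and it shows that this chain carbon, left with its hydrogen in the earlier compounds, can take a hexyl group with a large move toward stronger inhibition. The earlier change at the acid end could not show the size of any effect, since the value of compound 2 is a limit of the assay and not a number: the limit of > 1000000 nM in this assay, at which 1 of the 3 values shown sits.

What remains open is whether the step depends on the length or shape of the branch, since a shorter chain such as butyl, a longer chain such as octyl, or a phenyl ring on the same carbon is not among the compounds shown. Also open, from the compounds shown here alone, is whether hexyl would have a similar effect on the longer acid chain of compound 2, or whether an amide in place of the carboxylic acid would keep the number seen for compound 3.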